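The source may report more compounds than this note shows. Statements on the series, on what has been measured and on what is new or still open speak of the compounds shown alone.

Measured in a functional assay on Huh-7 cells (Homo sapiens) for inhibition, read by MTT assay, with a stated time of 48 h; a lower number here means a stronger inhibitor, a higher number a weaker inhibitor:
compound 1 `COc1ccc2c(=O)c(/C=C/C(=O)NCc3ccccc3F)coc2c1`: 8450 nM
compound 2 `COc1ccc(NC(=O)/C=C/c2coc3cc(OC)ccc3c2=O)cc1`: > 100000 nM

Compound 2 gives only a limit in this assay, > 100000 nM, and the limit of > 100000 nM in this assay, at which 1 of the 2 values shown sits, marks this. Among the compounds with values here, the single measured step, an at least 11-fold higher number from compound 1 to compound 2 (1.07 log units; beyond the scatter), concerns the group on the amide nitrogen. Compound 3 `COc1ccc2c(=O)c(/C=C/C(=O)Nc3ccc(C)cc3)coc2c1` differs from compound 2 by methyl in place of methoxy on an aromatic carbon, a change at a spot the measured step does not touch, so no step beyond the scatter is expected. The step of a number no higher from compound 2 to compound 3 (the limit leaves the size open) is the expected outcome, which may again end at a limit. The estimate for compound 3 is 100000 nM, between 30000 nM and 300000 nM.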

Compound 3, half-maximal inhibitory concentration: > 100000 nM
Compound 3: only a limit was reported; the forecaster's own chance of this, stated with the estimate: 65%; the middle value sits exactly at the limit.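

Swapping 2-fluorobenzyl for 4-methylphenyl on the amide nitrogen gives an at least 11-fold higher number from compound 1 to compound 3 (1.07 log units; beyond the scatter), so the loss seen with 4-methoxyphenyl does not depend on the methoxy group: a second 4-substituted phenyl group behaves the same way. Compound 2 and compound 3 both stop at a limit, so the step between them cannot be read and methoxy and methyl cannot be ranked: the limit of > 100000 nM in this assay, at which 2 of the 3 values shown sit.

On these data alone, what remains open is which feature of the 2-fluorobenzyl group matters in compound 1. A plain benzyl group or a 4-methylbenzyl group on the same nitrogen would help separate the role of the fluorine from that of the carbon linking the ring to the nitrogen.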